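Swapping the Aryl Arm of Compound 1 for an Ether

The source may report more compounds than this note shows. Statements on the series, on what has been measured and on what is new or still open speak of the compounds shown alone.

In an ADME assay on HepG2 cells (Homo sapiens) for cytotoxicity, read by luminescence, CellTiter-Glo and ATP content, with a stated time of 72 h (on this read-out higher numbers stand for an effect only at larger amounts of compound and lower numbers for an effect already at smaller amounts), compound 1 `COc1cccc(CNCCCNc2ccnc3cc(-c4ccc(F)cc4)ccc23)c1O` gives 6840 nM, the highest of the two numbers measured, while compound 2 `COc1ccc(F)cc1CNCCCNc1ccnc2cc(-c3ccc(F)cc3)ccc12` gives 770 nM in this assay. Within the data shown here, the one measured step, an 8.9-fold lower number from compound 1 to compound 2 (0.95 log units; beyond the scatter), concerns a change on the saturated chain carbon bound to an amine nitrogen, a different part of the shared core. Compound 3 `COc1ccccc1Oc1ccc2c(NCCCNCc3cccc(OC)c3O)ccnc2c1` has not yet been measured in this assay. It differs from compound 1 by 2-methoxyphenoxy in place of 4-fluorophenyl on an aromatic carbon. Among the measured compounds shown here, no measured step touches this position on the shared core, and the step from compound 1 to compound 2 offers no guide for it. With nothing bearing on the change, the expectation is a step of a 1.0-fold lower number from compound 1 to compound 3 (0.00 log units; within the scatter), which means none beyond the scatter. Compound 3 is accordingly estimated at 6800 nM, with a range from 2500 nM to 18000 nM.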

Compound 3, half-maximal effective concentration: 11200 nM
For compound 3 the middle estimate is 1.6-fold (0.22 log units) below the measured one; low and high end bracket the measured number.
By their numbers in this assay, from the lowest: compound 2; then compounds 1 and 3 (each within the scatter of the next).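

In this assay, the change on this aromatic carbon gives a 1.6-fold higher number from compound 1 to compound 3 (0.21 log units; within the scatter), even though 2-methoxyphenoxy has more heavy atoms than 4-fluorophenyl and brings hydrogen-bond acceptors where 4-fluorophenyl has none. This position can therefore carry either of these two aromatic groups without a shift that can be told from the scatter, whereas the change at the other site gives an 8.9-fold lower number from compound 1 to compound 2 (0.95 log units; beyond the scatter), which lies beyond it. No measurement shown here bears on why this swap leaves the number within the scatter.

One pair cannot show how this position responds to groups of other kinds, such as an amine or a carboxylic acid on this carbon. Also open, as far as these compounds go, is whether 2-methoxyphenoxy would behave the same way on compound 2, which carries 5-fluoro-2-methoxyphenyl on the chain.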